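The source may report more compounds than this note shows. Statements on the series, on what has been measured and on what is new or still open speak of the compounds shown alone.

In an ADME assay on Vero cells (Chlorocebus sabaeus) for cytotoxicity, read by reporter gene assay, with a stated time of 4 days (on this read-out higher numbers stand for weaker inhibition and lower numbers for stronger inhibition), compound 1 (`CCCCCCC(=O)NCC(C)(C)CC1=C(O)C(=O)c2ccccc2C1=O`) gives 24800 nM and compound 2 (`CCCCCCCCCCC(=O)NCC(C)(C)CC1=C(O)C(=O)c2ccccc2C1=O`) gives 14900 nM. Compound 3 (`CCCCCCCC(=O)OCC(C)(C)CC1=C(O)C(=O)c2ccccc2C1=O`) stands at > 258000 nM, which is a limit of the assay and not a number. Compound 4 (`CCCCCCCCCCCCCCCCCC(=O)OCC(C)(C)CC1=C(O)C(=O)c2ccccc2C1=O`) has decyl in place of hydrogen on a saturated chain carbon, seven bonds along the chain from a carbonyl carbon. Going by the values given here, the one measured step that bears on this is a 1.7-fold lower number from compound 1 to compound 2 (0.22 log units; within the scatter), a butyl addition in the amides, and no ester pair has been measured. Nothing beyond the scatter is therefore expected in this assay, and the estimated step is an at least 1.4-fold lower number from compound 3 to compound 4 (0.15 log units; that floor lies within the scatter). Compound 4 is estimated at 180000 nM, with an expected range of 50000 nM to 300000 nM.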

Compound 4, half-maximal inhibitory concentration: 15500 nM
Compound 4: middle estimate off by 12-fold (1.06 log units), on the high side; measured number below the stated range.
By their numbers in this assay, from the lowest: compounds 2, 4 and 1 (each within the scatter of the next). At a limit, above all of these: compound 3.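

In this assay, decyl in place of hydrogen on a saturated chain carbon, seven bonds along the chain from a carbonyl carbon, gives an at least 16-fold lower number from compound 3 to compound 4 (1.22 log units; beyond the scatter). The amide pair, with butyl at a position six bonds along the chain, had shown a 1.7-fold lower number from compound 1 to compound 2 (0.22 log units; within the scatter), so this is the first step in the series beyond the scatter. The value of compound 3 is a limit, so the step is a floor: the limit of > 258000 nM in this assay, at which 1 of the 4 values shown sits.

From the compounds shown here alone, how the number moves at chain lengths between those of compound 3 and compound 4 stays open, as does the effect of a terminal amine on the chain. Going by these compounds, what the ester linkage itself contributes also remains open.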